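The source may hold more compounds than are shown below. What is called first, only, known or untested is meant among the compounds shown, and "the series" means these compounds.

The measured compounds in a functional assay on CCRF-CEM cells (Homo sapiens) for inhibition, read by cell counting, with a stated time of 72 h (a lower number here means a stronger inhibitor, a higher number a weaker inhibitor), are these.
Compound 1, `CCN(CC)CN1C(=O)/C(=N/NC(=S)Nc2ccc(Cl)cc2)c2cc(Cl)ccc21`, gives only a limit of the assay, > 125000 nM, and no number.
Compound 2, `CCN(CC)CN1C(=O)/C(=N/NC(=S)Nc2ccccc2)c2cc(Cl)ccc21`, gives 40000 nM.
Compound 3, `CCN(CC)CN1C(=O)/C(=N/NC(=S)Nc2ccccc2)c2ccccc21`, gives 11000 nM.

Among these, compound 3 stands lowest of the two real numbers; its nearest neighbour is compound 2, and the step between them is a 3.6-fold lower number from compound 2 to compound 3 (0.56 log units; beyond the scatter), brought about by hydrogen in place of chloro on an aromatic carbon of the shared core. Compound 4, `CCN(CC)CN1C(=O)/C(=N/NC(=S)Nc2ccc(Cl)cc2)c2ccccc21`, is not yet measured. It differs from compound 3 in one place: chloro in place of hydrogen on an aromatic carbon. This is the reverse of the change that leads from compound 1 to compound 2, where hydrogen replaced chloro on the aromatic carbon para to a large group, and where the result was an at least 3.1-fold lower number from compound 1 to compound 2 (0.49 log units; beyond the scatter). That step is known only as a bound because the value of compound 1 is a limit (the limit of > 125000 nM in this assay, at which 1 of the 3 values shown sits), so the true step may be larger. Read backwards, adding chloro to compound 3 is expected to raise the number, making compound 4 a weaker inhibitor, with an estimated step of a 3.6-fold higher number from compound 3 to compound 4 (0.56 log units; beyond the scatter). The estimate for compound 4 in this assay is therefore 40000 nM, between 15000 nM and 125000 nM, with some chance that only a limit is returned.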

Compound 4, half-maximal inhibitory concentration: 10000 nM
The estimate for compound 4 lay 4.0-fold (0.60 log units) above the measured number; the measured number lies below the stated range.
By their numbers in this assay, from the lowest: compounds 4 and 3 (each within the scatter of the next); then compound 2. At a limit, above all of these: compound 1.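

In this assay, exchanging phenyl for 4-chlorophenyl leaves the number essentially unchanged on the core of compound 3, with a 1.1-fold lower number from compound 3 to compound 4 (0.04 log units; within the scatter). The earlier pair suggested that this chloro weakens inhibition wherever it sits on that ring, but its effect instead depends on the core that carries it, the one difference between the two pairs being the chloro on the core of compounds 1 and 2: the same change on two cores in this assay, an at least 3.1-fold lower number (0.49 log units; beyond the scatter) from compound 1 to compound 2 and a 1.1-fold higher number (0.04 log units; within the scatter) from compound 4 to compound 3, at least 3.4-fold (0.53 log units) apart, beyond the scatter of two such steps

Seen from the other side, removing the chloro from the core matters more when the 4-chlorophenyl group is present, with an at least 12-fold lower number from compound 1 to compound 4 (1.09 log units; beyond the scatter), so the two chloro groups do not act independently: the same change on two cores in this assay, a 3.6-fold lower number (0.56 log units; beyond the scatter) from compound 2 to compound 3 and an at least 12-fold lower number (1.09 log units; beyond the scatter) from compound 1 to compound 4, at least 3.4-fold (0.53 log units) apart, beyond the scatter of two such steps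

Compound 1 gives only a limit of the assay, > 125000 nM, so the true size of both steps out of it remains open: the limit of > 125000 nM in this assay, at which 1 of the 4 values shown sits.

Also open, on these data alone, is whether a fluoro, a methyl or a methoxy group on the aromatic carbon para to a large group would behave like chloro, on either core.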